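Swapping Phenyl for Propenyl on an Amide-Capped Amino Alcohol

A few compounds are considered here, and "the series" means these few. Any claim that something is new, unique, unknown or untested is made for them only; others in the source may bear on it.

compound 1, `CCCCCCCCCCCCCCCCCCNC(=O)[C@@H](N)[C@@H](C)O`: 44500 nM
compound 2, `CCCCCCCCCCCCCCCCCCNC(=O)[C@@H](NC(=O)/C=C/c1ccccc1)[C@@H](C)O`: 128000 nM

Of the two numbers in a functional assay on HepG2 cells (Homo sapiens) for cytotoxicity, read by MTT assay, with a stated time of 48 h (on this read-out lower numbers stand for stronger inhibition and higher numbers for weaker inhibition), compound 2 holds the higher one, set apart by a 2.9-fold higher number from compound 1 to compound 2 (0.46 log units; beyond the scatter). Compound 3, `C/C=C/C=C/C(=O)N[C@H](C(=O)NCCCCCCCCCCCCCCCCCC)[C@@H](C)O`, differs from compound 2 in one place: prop-1-en-1-yl in place of phenyl on a double-bonded chain carbon bound to a double-bonded chain carbon. For the measured compounds named here, no measured step tests this swap; the only step, a 2.9-fold higher number from compound 1 to compound 2 (0.46 log units; beyond the scatter), concerns adding the whole cap to the amine nitrogen and so says little about what sits at its far end. A change within the scatter, in no fixed direction, is therefore expected. Compound 3 is estimated to give 110000 nM in this assay, with a range from 45000 nM to 270000 nM. That estimate means a step of a 1.2-fold lower number from compound 2 to compound 3 (0.07 log units; within the scatter).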

Compound 3, half-maximal inhibitory concentration: 284000 nM
Estimate against measurement, compound 3: 2.6-fold (0.41 log units) below, outside the stated range (above it).
By their numbers in this assay, from the lowest: compound 1; then compound 2; then compound 3.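

In this assay, the group on the double-bonded chain carbon does matter: prop-1-en-1-yl in place of phenyl gives a 2.2-fold higher number from compound 2 to compound 3 (0.35 log units; beyond the scatter), a change beyond the usual scatter. Putting (penta-1,3-dien-1-yl)carbonyl in place of hydrogen on the amine nitrogen gives a 6.4-fold higher number from compound 1 to compound 3 (0.80 log units; beyond the scatter), so both caps shown raise the number, this one further. Nothing measured here explains the difference between the two groups. Going by these compounds, whether a carboxylic acid or an amine in place of phenyl would move the number back toward that of compound 1 remains open.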